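Swapping a propyl chain for a pyrazole on the amide nitrogen

The source may hold more compounds than are shown below. What is called first, only, known or untested is meant among the compounds shown, and "the series" means these compounds.

Of the compounds shown here, three sharing one core have been measured in an assay on HEK293 cells for agonist activity at transient receptor potential cation channel subfamily M member 8 (Homo sapiens), read by fluorescence and calcium flux, with a stated time of 15 min; on this read-out higher numbers stand for an effect only at larger amounts of compound and lower numbers for an effect already at smaller amounts. Compound 1 `Cc1ccc(OCC(=O)N(Cc2cccs2)c2cccnc2)cc1` gives 198 nM. Compound 2 `Cc1ccc(OCC(=O)N(Cc2cccs2)c2ccn(C)n2)cc1` gives 855 nM. Compound 3 `CCCN(Cc1cccs1)C(=O)COc1ccc(C)cc1` gives 40 nM, the lowest of the three numbers, and its gaps to both others lie beyond the scatter.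

Compound 4 `Cc1ccc(OCC(=O)N(Cc2cccs2)c2c(C)n[nH]c2C)cc1` is not yet measured. It differs from compound 3 in one place: 3,5-dimethyl-1H-pyrazol-4-yl in place of propyl on an amide-type nitrogen. The two measured steps that bear on this both exchange an aromatic ring on that nitrogen for the propyl chain. One is a 5.0-fold lower number from compound 1 to compound 3 (0.69 log units; beyond the scatter); the other is a 21-fold lower number from compound 2 to compound 3 (1.33 log units; beyond the scatter). Read in reverse, putting a ring back where the propyl chain sits, they point to a clear rise in the number, and the ring entering here resembles the pyrazole of compound 2 more than the pyridine of compound 1.

Compound 4 is therefore expected to show a step of a 15-fold higher number from compound 3 to compound 4 (1.18 log units; beyond the scatter) in this assay. The estimated value for compound 4 is 600 nM, with a range from 150 nM to 2500 nM.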

Compound 4, half-maximal effective concentration: 0.3 nM
Beside the measured number, compound 4's estimate is 2000-fold (3.30 log units) above it, outside the stated range (below it).
By their numbers in this assay, from the lowest: compound 4; then compound 3; then compound 1; then compound 2.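

In this assay, a ring on the amide-type nitrogen is not in itself a loss: pyridin-3-yl and 1-methyl-1H-pyrazol-3-yl both gave higher numbers than propyl, yet 3,5-dimethyl-1H-pyrazol-4-yl gives a 130-fold lower number from compound 3 to compound 4 (2.12 log units; beyond the scatter) in this series. Among the compounds shown here, the choice of ring matters far more here than the earlier compounds suggested, with a 660-fold lower number from compound 1 to compound 4 (2.82 log units; beyond the scatter) and a 2900-fold lower number from compound 2 to compound 4 (3.45 log units; beyond the scatter) on the same core, so two differently substituted pyrazoles stand at opposite ends of the series. No supporting data are available to explain this gain.

As far as these compounds go, it remains open whether the two methyl groups, the ring hydrogen on nitrogen or the attachment through carbon 4 of the pyrazole matters most. An unsubstituted 1H-pyrazol-4-yl and a 1,3,5-trimethyl-1H-pyrazol-4-yl on the same nitrogen would separate these features.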